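From propylsulfanyl to pyrrolidin-1-yl at a shared limit

The source may report more compounds than this note shows. Statements on the series, on what has been measured and on what is new or still open speak of the compounds shown alone.

- Compound 1 `CC(C)CSc1nc(N)nc2c1ncn2/C=C1/CC1(CO)CO`: > 20000 nM (a limit)
- Compound 2 `Nc1nc(OCc2ccccc2)c2ncn(/C=C3/CC3(CO)CO)c2n1`: > 20000 nM (a limit)
- Compound 3 `CCCSc1nc(N)nc2c1ncn2/C=C1/CC1(CO)CO`: > 20000 nM (a limit)

In an ADME assay on Akata cells (Homo sapiens) for cytotoxicity, with a stated time of 7 days (on this read-out higher numbers stand for lower toxicity in this test and lower numbers for higher toxicity in this test), compound 3 stands at > 20000 nM, which is a limit and not a number. It has no standing of its own among the three compounds, which all share one result: the limit of > 20000 nM in this assay, at which 3 of the 3 values shown sit.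

The next compound, compound 4 `Nc1nc(N2CCCC2)c2ncn(/C=C3/CC3(CO)CO)c2n1`, carries pyrrolidin-1-yl in place of propylsulfanyl on an aromatic carbon. Among the measured compounds shown here, the new group brings a five-membered non-aromatic ring, which none of the measured groups at that place has.

Two measured steps also exchange the group on this aromatic carbon. Benzyloxy in place of isobutylsulfanyl gives a step that the two limits leave unreadable from compound 1 to compound 2, and propylsulfanyl in place of benzyloxy gives a step that the two limits leave unreadable from compound 2 to compound 3. Shortening the chain gives a step that the two limits leave unreadable from compound 1 to compound 3. None of these steps has a readable size, so they offer no measured move to carry over, and no step beyond the scatter can be predicted in either direction.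

The expected step is therefore small, a number no higher from compound 3 to compound 4 (the limit leaves the size open), and another limit in this assay is the likeliest report. The estimate for compound 4 is 20000 nM, within an expected range of 8000 nM to 40000 nM.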

Compound 4, half-maximal cytotoxic concentration: > 24000 nM
Compound 4: no number, only a limit; the forecaster's own chance of this, stated with the estimate: 75%; middle value at least 1.2-fold (0.07 log units) away from the limit.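

In this assay compound 4 gives > 24000 nM, which is a limit and not a number. Among the compounds shown here, compound 1, compound 2 and compound 3 also report limits, so no step to compound 4 can be read. The compounds shown leave open whether any of these groups on the aromatic carbon changes toxicity in this test, and by how much.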